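Amide substituent variation on the shared core

A few compounds are considered here, and "the series" means these few. Any claim that something is new, unique, unknown or untested is made for them only; others in the source may bear on it.

Compound 3 `CCn1c(C(=O)Nc2cccc(C(F)(F)F)c2)ccc1C(CC)(CC)c1ccc(OCCC(O)(CC)CC)c(C)c1` closes the measured set. In a functional assay on HepG2 cells (Homo sapiens) for antiproliferative activity, read by MTT assay, with a stated time of 48 h (on this read-out lower numbers stand for stronger inhibition and higher numbers for weaker inhibition), compound 3 gives > 50000 nM, which is a limit of the assay and not a number. Compound 1 `CCN(CC)CCNC(=O)c1ccc(C(CC)(CC)c2ccc(OCCC(O)(CC)CC)c(C)c2)n1CC` gives 230 nM in this assay. Compound 2 `CCn1c(C(=O)N(CCC#N)CCC#N)ccc1C(CC)(CC)c1ccc(OCCC(O)(CC)CC)c(C)c1` gives 46300 nM in this assay. The two departures from compound 1 at the carbonyl carbon are both large losses: a 200-fold higher number from compound 1 to compound 2 (2.30 log units; beyond the scatter), and an at least 210-fold higher number from compound 1 to compound 3 (2.33 log units; beyond the scatter). Between the two weak compounds the comparison is an at least 1.0-fold higher number from compound 2 to compound 3 (0.03 log units; that floor lies within the scatter), so they are not separated. Compound 3 stands at the limit of > 50000 nM in this assay, at which 1 of the 3 values shown sits, the weak end of what is shown.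

Compound 4 `CCn1c(C(=O)N(C)CC(=O)O)ccc1C(CC)(CC)c1ccc(OCCC(O)(CC)CC)c(C)c1` carries a further change at the same carbonyl carbon: (carboxymethyl)(methyl)amino in place of (3-(trifluoromethyl)phenyl)amino on a carbonyl carbon. Among the measured compounds shown here, no measured step covers this exchange. What bears on it is indirect: every replacement of the 2-(diethylamino)ethyl group of compound 1 shown so far, whether by the nitrile-bearing chains of compound 2 or by the 3-(trifluoromethyl)phenyl group of compound 3, was a large upward step. Nothing shown points to a recovery with the (carboxymethyl)(methyl)amino group, so the expected step that the limit leaves unreadable from compound 3 to compound 4 is none beyond the scatter, and compound 4 is expected to remain at or near the limit. The estimate for compound 4 is 60000 nM, with a range from 15000 nM to 200000 nM.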

Compound 4, half-maximal inhibitory concentration: 5710 nM
Estimate against measurement, compound 4: 11-fold (1.02 log units) above; measured number outside the range, below it.
By their numbers in this assay, from the lowest: compound 1; then compound 4; then compound 2. At a limit, above all of these: compound 3.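

At the carbonyl carbon, leaving the (2-(diethylamino)ethyl)amino group does not always bring the number to the weak end, and in this assay the (carboxymethyl)(methyl)amino group separates from both earlier replacements, with an at least 8.7-fold lower number from compound 3 to compound 4 (0.94 log units; beyond the scatter) and an 8.1-fold lower number from compound 2 to compound 4 (0.91 log units; beyond the scatter). This recovery is only partial, since the (2-(diethylamino)ethyl)amino group remains clearly preferred, with a 25-fold higher number from compound 1 to compound 4 (1.39 log units; beyond the scatter), so this position now shows three distinct levels of activity rather than one strong compound and a weak remainder. The step involving compound 3 is only a floor, as its value is a limit of the assay and not a number: the limit of > 50000 nM in this assay, at which 1 of the 4 values shown sits.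

The compounds shown leave open whether the low number of compound 1 depends on the diethylamino end of its chain or on the chain as a whole, which a 3-(diethylamino)propyl or a 2-(pyrrolidin-1-yl)ethyl group on the amide nitrogen would help to settle. They also leave open how much of the standing of compound 4 rests on its free carboxylic acid, which the corresponding methyl ester would test.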